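Arylthio series: cytotoxicity limits and an unsubstituted analogue

A few compounds are considered here, and "the series" means these few. Any claim that something is new, unique, unknown or untested is made for them only; others in the source may bear on it.

The series shares one core carrying an arylthio group whose distal ring is varied. In an ADME assay on HEK293 cells (Homo sapiens) for cytotoxicity, read by MTT assay, with a stated time of 24 h (a higher number here means a weaker inhibitor, a lower number a stronger inhibitor), compound 1 `N#CC1=C2C(=NC1=O)c1cccc3c(Sc4ccc(Br)cc4)ccc2c13` gives only a limit, > 50000 nM. Compound 2 `N#CC1=C2C(=NC1=O)c1cccc3c(Sc4ccc(N)cc4)ccc2c13` in this assay likewise gives only a limit, > 50000 nM. Compound 3 `CCC(C)(C)c1ccc(Sc2ccc3c4c(cccc24)C2=NC(=O)C(C#N)=C23)cc1` also reaches only a limit in this assay, > 50000 nM. Because all three values sit at the limit of > 50000 nM in this assay, at which 3 of the 3 values shown sit, the steps a step that the two limits leave unreadable from compound 1 to compound 2, a step that the two limits leave unreadable from compound 1 to compound 3 and a step that the two limits leave unreadable from compound 2 to compound 3 cannot be read, and compound 3 cannot be placed against compound 1 or compound 2 beyond the statement that none of the three shows a measurable number.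

Compound 4 `N#CC1=C2C(=NC1=O)c1cccc3c(Sc4ccccc4)ccc2c13` differs from compound 3 by hydrogen in place of 1,1-dimethylpropyl on an aromatic carbon. Going by the values given here, no measured step bears on this change in a readable way, since the three steps are all hidden by the limit. With nothing in the series pointing away from the limit, compound 4 is expected to give in this assay 60000 nM with a range of 20000 nM to 200000 nM, which means an expected step that the limit leaves unreadable from compound 3 to compound 4 of no readable size, most probably again a limit rather than a number.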

Compound 4, half-maximal inhibitory concentration: > 50000 nM
Compound 4 ended at the assay's limit (the forecaster's own chance of this, stated with the estimate: 85%); the middle value lies beyond the limit too.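

In this assay the steps to compound 4 from compound 1, compound 2 and compound 3 cannot be read, so the result adds no new step: the limit of > 50000 nM in this assay, at which 4 of the 4 values shown sit.

The compounds shown leave open whether any change on the distal ring gives a measurable value in this assay and how large any difference would be.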